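Compound 3 to compound 4: a single eight-membered ring

The source may hold more compounds than are shown below. What is called first, only, known or untested is meant among the compounds shown, and "the series" means these compounds.

Compound 1 `Cc1cc(S(=O)(=O)N2C=CNC(=O)[C@H]2CC(=O)N[C@H]2CCN(C)CC2(C)C)c(C)cc1Cl`: 87 mL.min-1.g-1
Compound 2 `Cc1cc(S(=O)(=O)N2C=CNC(=O)[C@H]2CC(=O)N2CC[C@H](N3CCCC3)C2)c(C)cc1Cl`: 265 mL.min-1.g-1
Compound 3 `Cc1cc(S(=O)(=O)N2C=CNC(=O)[C@H]2CC(=O)N2CCC[C@H](N3CCCC3)C2)c(C)cc1Cl`: 235 mL.min-1.g-1

In an in vitro ADME assay on microsomes from liver (Homo sapiens) for pharmacokinetics (on this read-out higher numbers stand for fast clearance and lower numbers for slow clearance), compound 3 gives 235 mL.min-1.g-1 and sits together with compound 2 in the upper part of the three numbers, clear of compound 1. Compound 4 `Cc1cc(S(=O)(=O)N2C=CNC(=O)[C@H]2CC(=O)N2CCCCC(N(C)C)CC2)c(C)cc1Cl` has not yet been measured. Its structural change from compound 3 is a group of 11 heavy atoms (9 carbon, 2 nitrogen; one eight-membered non-aromatic ring with 1 hetero atom) in place of a group of 11 heavy atoms (9 carbon, 2 nitrogen; one five-membered non-aromatic ring with 1 hetero atom, one six-membered non-aromatic ring with 1 hetero atom), on a carbonyl carbon and the rest of the molecule stays the same.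

Among the measured compounds shown here, three measured steps bear on this change, since each one exchanges the group on the same carbonyl carbon. The step of a 1.1-fold lower number from compound 2 to compound 3 (0.05 log units; within the scatter) shows no change beyond the scatter. The steps of a 3.0-fold higher number from compound 1 to compound 2 (0.48 log units; beyond the scatter) and a 2.7-fold higher number from compound 1 to compound 3 (0.43 log units; beyond the scatter) are modest and are the largest seen for any exchange of this group. For the measured compounds named here, no measured compound carries an eight-membered ring, so the data offer no direct precedent.

On this limited evidence, an estimated step of a 1.2-fold lower number from compound 3 to compound 4 (0.07 log units; within the scatter) is expected, which means no clear shift in either direction. The estimated value for compound 4 is 200 mL.min-1.g-1 in this assay, with a range of 90 mL.min-1.g-1 to 420 mL.min-1.g-1 expected.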

Compound 4, intrinsic clearance in microsomes: 60 mL.min-1.g-1
The estimate for compound 4 lay 3.3-fold (0.52 log units) above the measured number, outside the stated range (below it).
By their numbers in this assay, from the lowest: compounds 4 and 1 (each within the scatter of the next); then compounds 3 and 2 (each within the scatter of the next).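

On the carbonyl carbon, a group with the same 11 heavy atoms (9 carbon, 2 nitrogen) can still move the number in this assay beyond the scatter: one eight-membered non-aromatic ring in place of the two-ring group gives a 3.9-fold lower number from compound 3 to compound 4 (0.59 log units; beyond the scatter) and, against the group with 2 five-membered non-aromatic rings, a 4.4-fold lower number from compound 2 to compound 4 (0.65 log units; beyond the scatter) as the largest steps yet seen at this place. With a 1.5-fold lower number from compound 1 to compound 4 (0.16 log units; within the scatter) compound 4 falls in with compound 1, so the two compounds with a single ring in this group now stand at the low end and the two with two rings at the high end, and none of the four goes against that split. No measurement shown accounts for this shift, and no cause can be given for it.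

Among the compounds shown here, the four compounds do not separate the number of rings from ring size, and the single-ring side rests on only two examples. On these data alone, whether a seven-membered ring built from the same atoms, or a group with a ring oxygen such as a morpholine, would sit with compound 1 and compound 4 or with compound 2 and compound 3 remains open.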